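Cytotoxicity of Three Amide Variants and a Fourth

This account rests on a few compounds, and the source may have more. Where it says the series, first, only, none or still open, it means among the compounds named here.

Measured compounds:
- Compound 1, `CC(=O)Oc1ccc(/C=C/S(=O)(=O)CCc2ccc(NC(=O)c3ccccc3)cc2)cc1OC(C)=O`: 108000 nM
- Compound 2, `CC(=O)Oc1ccc(/C=C/S(=O)(=O)CCc2ccc(NC(=O)c3ccc(F)cc3)cc2)cc1OC(C)=O`: 162000 nM
- Compound 3, `CC(=O)Oc1ccc(/C=C/S(=O)(=O)CCc2ccc(NC(=O)C3CCCCC3)cc2)cc1OC(C)=O`: 169000 nM

All three were tested in an ADME assay on TZM cells (Homo sapiens) for cytotoxicity, read by CCK-8 assay, with a stated time of 2 days; on this read-out lower numbers stand for higher toxicity in this test and higher numbers for lower toxicity in this test. Compound 3 gives the highest of the three numbers, but its steps to the other two, a 1.6-fold higher number from compound 1 to compound 3 (0.19 log units; within the scatter) and a 1.0-fold higher number from compound 2 to compound 3 (0.02 log units; within the scatter), both fall within the scatter of repeated measurements, so the three compounds cannot be told apart on this read-out. The step of a 1.5-fold higher number from compound 1 to compound 2 (0.18 log units; within the scatter) is likewise within the scatter.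

Compound 4, `CC(=O)Oc1ccc(/C=C/S(=O)(=O)CCc2ccc(NC(=O)c3ccc(C)cc3)cc2)cc1OC(C)=O`, has not yet been tested. It differs from compound 3 by the change (4-methylphenyl in place of cyclohexyl on a carbonyl carbon). The two measured steps that bear on this place, from compound 1 to compound 3 and from compound 2 to compound 3, were both small, so moving from cyclohexyl back to an aromatic group is expected to change the number in this assay by no more than the scatter; the estimated step is a 1.2-fold lower number from compound 3 to compound 4 (0.08 log units; within the scatter). Compound 4 is therefore expected to give about 140000 nM, with a range of 75000 nM to 260000 nM.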

Compound 4, half-maximal cytotoxic concentration: 177000 nM
Compound 4: the middle estimate sits 1.3-fold (0.10 log units) below what was measured; low and high end bracket the measured number.
By their numbers in this assay, from the lowest: compounds 1, 2, 3 and 4 (each within the scatter of the next).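

In this assay, the aromatic ring on the carbonyl carbon now carries a methyl group, and the three comparisons are a 1.0-fold higher number from compound 3 to compound 4 (0.02 log units; within the scatter) for 4-methylphenyl in place of cyclohexyl, a 1.1-fold higher number from compound 2 to compound 4 (0.04 log units; within the scatter) for methyl in place of fluoro, and a 1.6-fold higher number from compound 1 to compound 4 (0.21 log units; within the scatter) for methyl in place of hydrogen. Adding a carbon group to that ring therefore produces no step beyond the scatter, and all four compounds remain indistinguishable on this read-out. Nothing available here offers an explanation for this flat result.

As far as these compounds go, all four groups at this place are six-membered rings, so it remains open whether an amine, a carboxylic acid or a longer open chain would give a step beyond the scatter. From the compounds shown here alone, whether the same holds with a changed core also remains open.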